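From Urea to Amide in a Pyrazole Series

This account rests on a few compounds, and the source may have more. Where it says the series, first, only, none or still open, it means among the compounds named here.

Compound 1 `COc1cc(Cl)cc(-c2nn(-c3cccc(NC(=O)Nc4ccc(Cl)c(C(F)(F)F)c4)c3)cc2-c2ccncc2)c1` and compound 2 `COc1cc(Cl)cc(-c2nn(-c3cccc(NC(=O)Nc4cccc(C(F)(F)F)c4)c3)cc2-c2ccncc2)c1` share a core and differ by a single hydrogen in place of chloro on an aromatic carbon. Within the data shown here, in a functional assay on OVCAR-4 cells (Homo sapiens) for inhibition, read by sulforhodamine B assay, with a stated time of 48 h, tested at 0.01 uM (a higher number here means a weaker effect of the compound at the concentration tested, a lower number a stronger effect), compound 1 gives 99%, and compound 2 gives 93%; the one step measured, a number 6 percentage points lower from compound 1 to compound 2 (within the scatter), lies within the scatter, so compound 2 stands level with compound 1 among the two numbers. Compound 3 `COc1cc(Cl)cc(-c2nn(-c3cccc(NC(=O)c4cccc(C(F)(F)F)c4)c3)cc2-c2ccncc2)c1` carries 3-(trifluoromethyl)phenyl in place of (3-(trifluoromethyl)phenyl)amino on a carbonyl carbon. Among the measured compounds shown here, no measured step touches this change, so the best estimate for compound 3 in this assay is 94%, between 80% and 105%, with a number 1 percentage points higher from compound 2 to compound 3 (within the scatter) expected to stay within the scatter.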

Compound 3, a percentage reported as activity, at one concentration (the size of the read-out at that concentration, not a potency): 106%
Estimate against measurement, compound 3: 12 percentage points below; measured number above the stated range.
By their numbers in this assay, from the lowest: compounds 2, 1 and 3 (each within the scatter of the next, the first and the last beyond it).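

In this assay the change on the carbonyl carbon, 3-(trifluoromethyl)phenyl in place of (3-(trifluoromethyl)phenyl)amino, gives a number 13 percentage points higher from compound 2 to compound 3 (beyond the scatter) and so a modestly weaker effect, a separation the chloro step did not show. The larger replacement, which also removes the chloro, gives a number 7 percentage points higher from compound 1 to compound 3 (within the scatter) and so shows no clear separation. No measured evidence here accounts for the step. Still open, on these data alone, is how an amine or a benzyl group on this carbonyl carbon would behave, and whether adding chloro to compound 3 would change its number.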